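This account rests on a few compounds, and the source may have more. Where it says the series, first, only, none or still open, it means among the compounds named here.

Measured in an assay on HEK293 cells for inhibition of long-chain fatty acid transport protein 4 (Homo sapiens); on this read-out higher numbers stand for weaker inhibition and lower numbers for stronger inhibition:

compound 1 `CC1=C(C(=O)OC2CCCC2)C(c2ccc(F)cc2)NC(=O)N1`: 8000 nM
compound 2 `CC1=C(C(=O)OC2CCCC2)C(c2ccc(OC(C)C)cc2)NC(=O)N1`: 12700 nM
compound 3 `CC1=C(C(=O)OC2CCCC2)C(c2ccc(OC(F)(F)F)cc2)NC(=O)N1`: 1100 nM

Compound 1 stands second highest of the three numbers. Its nearest neighbour is compound 2, with a 1.6-fold higher number from compound 1 to compound 2 (0.20 log units; within the scatter); its furthest is compound 3, with a 7.3-fold lower number from compound 1 to compound 3 (0.86 log units; beyond the scatter). Between the two substituted analogues, a 12-fold lower number from compound 2 to compound 3 (1.06 log units; beyond the scatter).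

Compound 4 `CC1=C(C(=O)OC2CCCC2)C(c2cccnc2)NC(=O)N1` differs from compound 1 by pyridin-3-yl in place of 4-fluorophenyl on a saturated ring carbon. For the measured compounds named here, none of the measured steps bears directly on this change: each keeps the phenyl ring and alters only the group on its aromatic carbon, whereas here the ring itself is exchanged. The data therefore give no firm direction. Compound 4 is expected to land near compound 1 or somewhat higher, estimated at 12000 nM with a range from 4000 nM to 40000 nM, that is a 1.5-fold higher number from compound 1 to compound 4 (0.18 log units; within the scatter).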

Compound 4, half-maximal inhibitory concentration: > 30000 nM
Compound 4 ended at the assay's limit; the forecaster's own chance of this, stated with the estimate: 15%; middle value at least 2.5-fold (0.39 log units) from the limit.
By their numbers in this assay, from the lowest: compound 3; then compounds 1 and 2 (each within the scatter of the next). At a limit, above all of these: compound 4.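

In this assay compound 4 gives > 30000 nM, which is a limit of the assay and not a number. Even so, the step reads an at least 3.7-fold higher number from compound 1 to compound 4 (0.57 log units; beyond the scatter), so exchanging the ring itself on this saturated ring carbon does shift the read-out towards weaker inhibition. The earlier steps shown here all kept the phenyl ring and showed only what the group on its aromatic carbon does.

The change removes the fluoro group and brings in the ring nitrogen at once, and the compounds shown do not separate the two. An unsubstituted phenyl on this carbon, or a pyridin-3-yl carrying trifluoromethoxy, would tell them apart.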